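Swapping sec-Butyl for Cyclopropylmethyl on the Ester Oxygen

The source may report more compounds than this note shows. Statements on the series, on what has been measured and on what is new or still open speak of the compounds shown alone.

Of the compounds shown here, three sharing one core have been tested in an assay on membranes from CHO cells for displacement of a labelled ligand from adenosine receptor A1 (Homo sapiens), read by scintillation counting, with a stated time of 60 min, tested at 1 uM; on this read-out lower numbers stand for less inhibition and higher numbers for more inhibition at the one concentration tested (going by the name of the read-out). Compound 1 `CC1=C(C(=O)OC(C)(C)C)C(c2cccs2)NC(=O)N1` gives 26%. Compound 2 `CCSC(=O)C1=C(C)NC(=O)NC1c1cccs1` gives 6%, and compound 3 `CCC(C)OC(=O)C1=C(C)NC(=O)NC1c1cccs1` gives 5%, a number within the usual scatter of the one before it and well below the first. The steps leading to it read a number 1 percentage points lower from compound 2 to compound 3 (within the scatter) and a number 21 percentage points lower from compound 1 to compound 3 (beyond the scatter). Compound 4 `CC1=C(C(=O)OCC2CC2)C(c2cccs2)NC(=O)N1` differs from compound 3 in one place: cyclopropylmethyl in place of sec-butyl on an oxygen next to a carbonyl group. Among the measured compounds shown here, the only measured step at this oxygen is the change from tert-butyl to sec-butyl, a number 21 percentage points lower from compound 1 to compound 3 (beyond the scatter); it shows the group here can move the number, but nothing measured tells how cyclopropylmethyl compares. A small rise is expected, a number 5 percentage points higher from compound 3 to compound 4 (within the scatter), so compound 4 is estimated at 10%, between 0% and 30%.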

Compound 4, a percentage reported as inhibition, at one concentration (the size of the read-out at that concentration, not a potency): 23%
Compound 4: the middle estimate sits 13 percentage points below what was measured; low and high end bracket the measured number.
By their numbers in this assay, from the lowest: compounds 3 and 2 (each within the scatter of the next); then compounds 4 and 1 (each within the scatter of the next).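

Cyclopropylmethyl and sec-butyl carry the same count of carbon atoms, yet on this oxygen in this assay the swap gives a number 18 percentage points higher from compound 3 to compound 4 (beyond the scatter), so how those carbons are arranged can move the number. Cyclopropylmethyl in place of tert-butyl gives a number 3 percentage points lower from compound 1 to compound 4 (within the scatter), while cyclopropylmethoxy in place of ethylsulfanyl on the carbonyl carbon gives a number 17 percentage points higher from compound 2 to compound 4 (beyond the scatter), leaving sec-butyl and ethylsulfanyl as the changes with the lower numbers. No available evidence accounts for these steps. Going by these compounds, how a straight butyl chain or a cyclobutyl ring on this oxygen would read stays open, as does an amine in place of the oxygen.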